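A Thiophene Swap on a Weakly Active Chalcone Core

The compounds below may be only part of what the source reports. "The series", "measured", "known", "first", "only" and "open" are said of these compounds alone.

Compound 1, `COc1cccc(/C=C/C(=O)c2ccc(OC)c3c2OC(C)(C)C=C3)c1`: > 10000 nM (a limit of the assay)
Compound 2, `COc1cc(OC)c(OC)cc1/C=C/C(=O)c1ccc(OC)c2c1OC(C)(C)C=C2`: > 10000 nM (a limit of the assay)
Compound 3, `COc1ccc(C(=O)/C=C/c2ccc3ccccc3n2)c2c1C=CC(C)(C)O2`: 4530 nM

The three measured compounds share one core and differ only in the aromatic group on the double-bonded chain. In a functional assay on HCT-116 cells (Homo sapiens) for antiproliferative activity, read by MTT assay, with a stated time of 24 h (a higher number here means a weaker inhibitor, a lower number a stronger inhibitor), compound 1 gives only a limit, > 10000 nM, so its true potency is not known. Compound 2 likewise returns only a limit, > 10000 nM. Among the compounds with values here, compound 3 is the sole compound with a numerical value, 4530 nM. Compound 1 therefore stands at the weak end of what is shown, at the limit of > 10000 nM in this assay, at which 2 of the 3 values shown sit, and no step between two measured compounds is available to calibrate how much an aromatic swap can move the number.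

Compound 4, `COc1ccc(C(=O)/C=C/c2cccs2)c2c1C=CC(C)(C)O2`, carries thiophen-2-yl in place of 3-methoxyphenyl on a double-bonded chain carbon bound to a double-bonded chain carbon. Because compound 1 sits at the limit > 10000 nM, any gain for compound 4 would have to be sizeable before a number appears at all. The expected step of an at least 1.4-fold lower number from compound 1 to compound 4 (0.15 log units; that floor lies within the scatter) is small, toward somewhat stronger inhibition, and may not exceed the scatter. Compound 4 is estimated at 7000 nM, with a range from 3000 nM to 20000 nM, and could well return only a limit again.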

Compound 4, half-maximal inhibitory concentration: > 10000 nM
Compound 4 gave a limit, no number; the forecaster's own chance of this, stated with the estimate: 45%; middle value at least 1.4-fold (0.15 log units) away from the limit.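

Compound 1 and compound 4 each return only a limit, not a number, so no step from one to the other can be read: the limit of > 10000 nM in this assay, at which 3 of the 4 values shown sit.

The compounds shown leave open whether thiophen-2-yl in place of 3-methoxyphenyl shifts potency at all in this assay, and in which direction.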